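A Second Fluorine on the Aryl Ether Ring

A few compounds are considered here, and "the series" means these few. Any claim that something is new, unique, unknown or untested is made for them only; others in the source may bear on it.

Measured compounds so far:
compound 1 `Cc1nnsc1CO/N=C/c1c(C)nn(C)c1Oc1cccc(F)c1` — > 50000 nM
compound 2 `Cc1ccc(Oc2c(/C=N/OCc3snnc3C)c(C)nn2C)cc1` — 12800 nM
compound 3 `Cc1nnsc1CO/N=C/c1c(C)nn(C)c1Oc1cccc(F)c1F` — 25700 nM

All three compounds share the same core and differ only in the aromatic ring that hangs on the ether oxygen. In a functional assay on SGC-7901 cells (Homo sapiens) for inhibition, read by MTT assay, with a stated time of 48 h (a higher number here means a weaker inhibitor, a lower number a stronger inhibitor), compound 1 reaches only a limit, > 50000 nM, so its true value is not known as a number. Compound 2 gives 12800 nM in this assay. Compound 3 gives 25700 nM in this assay. Swapping the ring gave an at least 3.9-fold lower number from compound 1 to compound 2 (0.59 log units; beyond the scatter), while adding a single fluorine gave an at least 1.9-fold lower number from compound 1 to compound 3 (0.28 log units; that floor lies within the scatter).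

Compound 4 `Cc1nnsc1CO/N=C/c1c(C)nn(C)c1Oc1cc(F)cc(F)c1` is the next variation on compound 1: fluoro in place of hydrogen on an aromatic carbon. The closest measured parallel is the step from compound 1 to compound 3, which also adds one fluorine to the same ring and yielded an at least 1.9-fold lower number from compound 1 to compound 3 (0.28 log units; that floor lies within the scatter), a gain whose lower bound does not clear the scatter. Because compound 1 sits at the limit of > 50000 nM in this assay, at which 1 of the 3 values shown sits, any improvement can only be read against that limit. A small gain, or none beyond the scatter, is therefore expected: an at least 1.4-fold lower number from compound 1 to compound 4 (0.15 log units; that floor lies within the scatter). The estimate for compound 4 is 35000 nM, within a range from 15000 nM to 90000 nM.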

Compound 4, half-maximal inhibitory concentration: 9410 nM
The estimate for compound 4 lay 3.7-fold (0.57 log units) above the measured number; the whole stated range lies above it.
By their numbers in this assay, from the lowest: compounds 4, 2 and 3 (each within the scatter of the next, the first and the last beyond it). At a limit, above all of these: compound 1.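

The position of the second fluorine on the ring matters in this assay: with the same difluorophenyl type of ring, changing from 2,3-difluorophenyl to 3,5-difluorophenyl gave a 2.7-fold lower number from compound 3 to compound 4 (0.44 log units; beyond the scatter), while the comparison with the 4-methylphenyl ring gave a 1.4-fold lower number from compound 2 to compound 4 (0.13 log units; within the scatter), so compound 4 and compound 2 cannot be ranked against each other. Adding a fluoro group to the ring of compound 1, meta to the fluoro group already there, gave an at least 5.3-fold lower number from compound 1 to compound 4 (0.72 log units; beyond the scatter), and this time the floor of the step clears the scatter, which the step to compound 3 did not do. Compound 1 is held at a limit, so that step gives only a minimum and not a true size: the limit of > 50000 nM in this assay, at which 1 of the 4 values shown sits.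

Going by these compounds, it remains open whether a chloro, methoxy or trifluoromethyl group in these same places on the ring would act as the fluoro group does here, or whether a ring carrying an amine or a carboxylic acid would hold the number reached by compound 4. Why the 3,5-difluorophenyl ring gives a lower number than the 2,3-difluorophenyl ring also stays unexplained, since these values record only the size of the difference.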